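The source may hold more compounds than are shown below. What is called first, only, known or untested is meant among the compounds shown, and "the series" means these compounds.

Among the measured compounds shown here, compound 3, `CC(/C=N/Nc1ccc([N+](=O)[O-])cc1)=N\NC(=O)c1ccccc1I`, is the one member of this small set that returns a plain number: in a functional assay on cells (Splenocyte, Mus musculus, strain BALB/c) for inhibition, read by scintillation counting and thymidine incorporation, with a stated time of 72 h (a higher number here means a weaker inhibitor, a lower number a stronger inhibitor), compound 3 gives 2980 nM. Compound 1, `CC(/C=N/Nc1ccc([N+](=O)[O-])cc1)=N\NC(=O)c1ccccc1`, gives in this assay only the limit > 12000 nM. Compound 2, `CC(/C=N/Nc1ccc([N+](=O)[O-])cc1)=N\NC(=O)c1ccccc1F`, likewise gives only the limit > 12000 nM. Both values therefore sit at the limit of > 12000 nM in this assay, at which 2 of the 3 values shown sit, and the step from compound 1 to compound 2 is a step that the two limits leave unreadable from compound 1 to compound 2. For the measured compounds named here, the two steps that do read are an at least 4.0-fold lower number from compound 1 to compound 3 (0.60 log units; beyond the scatter) and an at least 4.0-fold lower number from compound 2 to compound 3 (0.60 log units; beyond the scatter), so the iodo group in compound 3 is the only change that has moved the number below the limit.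

Compound 4, `CC(/C=N/Nc1ccc([N+](=O)[O-])cc1)=N\NC(=O)c1ccc(Cl)cc1`, carries 4-chlorophenyl in place of 2-iodophenyl on a carbonyl carbon. Going by the values given here, no measured step covers this change directly; the steps in hand show only that the unsubstituted phenyl of compound 1 and the fluoro of compound 2 stay at the limit while the iodo of compound 3 does not. Going by these compounds, a chloro group at a different position on the ring is untested, so the expectation leans back toward the limit but without confidence. Compound 4 is therefore estimated to give 8000 nM, with a range from 2500 nM to 30000 nM. That amounts to an expected 2.7-fold higher number from compound 3 to compound 4 (0.43 log units; beyond the scatter).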

Compound 4, half-maximal inhibitory concentration: 4200 nM
The estimate for compound 4 lay 1.9-fold (0.28 log units) above the measured number, within the range that was stated.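

Among the compounds shown here, with compound 4, the iodo group of compound 3 is no longer the only change that brings the number below the limit: in this assay there is an at least 2.8-fold lower number from compound 1 to compound 4 (0.45 log units; beyond the scatter), and for the replacement of the 2-fluorophenyl there is an at least 2.8-fold lower number from compound 2 to compound 4 (0.45 log units; beyond the scatter). The remaining comparison is a 1.4-fold higher number from compound 3 to compound 4 (0.15 log units; within the scatter), so the 2-iodophenyl and 4-chlorophenyl groups cannot be told apart at this place on the carbonyl carbon, even though the two halogens and their places on the ring differ. Compound 1 and compound 2 each still give only a limit, not a number, so the two steps to compound 4 give no full size: the limit of > 12000 nM in this assay, at which 2 of the 4 values shown sit.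

Compound 4 differs from compound 3 in both the halogen and its place on the ring, so the compounds shown do not separate these two changes, nor do they show whether chloro in place of hydrogen would have the same outcome elsewhere on the ring. Going by these compounds, it also remains open whether a substituent that is not a halogen, such as an amine, a carboxylic acid or a methoxy group, would bring the number below the limit on this ring.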